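The compounds below may be only part of what the source reports. "The series", "measured", "known", "first", "only" and "open" are said of these compounds alone.

Series notes, step from compound 3 to compound 4. The shared core carries a 4-(trifluoromethoxy)phenyl group in compound 1 `Cc1cnc(Nc2ccc(C(=O)Nc3c(C)cccc3C)cc2)nc1-c1ccc(OC(F)(F)F)cc1`, which in an assay on NIH3T3 cells for inhibition of Sonic hedgehog protein (Mus musculus), read by a luciferase reporter, with a stated time of 48 h (on this read-out lower numbers stand for stronger inhibition and higher numbers for weaker inhibition), gives 1.3 nM. Compound 2 `Cc1cnc(Nc2ccc(C(=O)Nc3c(C)cccc3C)cc2)nc1-c1ccc(OC(F)(F)F)c(F)c1` adds a fluoro to that ring and in this assay gives 159 nM. Compound 3 `Cc1cnc(Nc2ccc(C(=O)Nc3c(C)cccc3C)cc2)nc1-c1ccoc1` carries furan-3-yl instead and in this assay gives 15.7 nM. Among these three numbers compound 3 stands second highest: its nearest neighbour is compound 2, with a 10-fold lower number from compound 2 to compound 3 (1.01 log units; beyond the scatter), and its furthest is compound 1, with a 12-fold higher number from compound 1 to compound 3 (1.08 log units; beyond the scatter).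

Compound 4 `Cc1cnc(Nc2ccc(C(=O)Nc3c(C)cccc3C)cc2)nc1Cc1ccccc1` is the unmeasured member. The change is benzyl in place of furan-3-yl on an aromatic carbon. For the measured compounds named here, no measured step exchanges the group at this place for a benzyl. Going by the values given here, two steps bear on it indirectly: a 12-fold higher number from compound 1 to compound 3 (1.08 log units; beyond the scatter) shows that swapping the ring at this place moves the number well beyond the scatter, and a 120-fold higher number from compound 1 to compound 2 (2.09 log units; beyond the scatter) shows that a single fluoro there does so as well. Among the compounds with values here, the direction for benzyl cannot be read from either, and every measured change at this place so far has raised the number. A modest further rise is therefore expected, a 2.5-fold higher number from compound 3 to compound 4 (0.41 log units; beyond the scatter). Compound 4 is estimated at 40 nM, with a range from 8 nM to 300 nM.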

Compound 4, half-maximal inhibitory concentration: 34.3 nM
Compound 4: the middle estimate sits 1.2-fold (0.07 log units) above what was measured; measured number inside the range.
By their numbers in this assay, from the lowest: compound 1; then compound 3; then compound 4; then compound 2.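

In this assay, for the compounds shown here, benzyl is the first group at this place whose ring is not bonded directly to the shared core, and it costs little relative to furan-3-yl, with a 2.2-fold higher number from compound 3 to compound 4 (0.34 log units; beyond the scatter). Its standing against the two substituted phenyl groups is split: there is a 26-fold higher number from compound 1 to compound 4 (1.42 log units; beyond the scatter), yet also a 4.6-fold lower number from compound 2 to compound 4 (0.67 log units; beyond the scatter), so a benzyl without any substituent lies inside the span already set by those two groups, and the presence of a directly bonded phenyl ring does not by itself give the lower number. Nothing available accounts for the size or direction of these steps.

Still open, going by these compounds, is whether a 4-(trifluoromethoxy) substituent on the benzyl ring would bring the number back toward that of compound 1, and whether a fluoro on that ring would again give a rise as large as a 120-fold higher number from compound 1 to compound 2 (2.09 log units; beyond the scatter). Also open, on these data alone, is how a longer chain such as phenethyl, or an amine such as piperidine, would compare with benzyl at this place.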